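The source may report more compounds than this note shows. Statements on the series, on what has been measured and on what is new or still open speak of the compounds shown alone.

Of the compounds shown here, two with a shared core have numbers so far in a physicochemical assay for solubility, measured as kinetic solubility, at pH 6.5; a lower number here means a less soluble compound, a higher number a more soluble compound. Going by the values given here, compound 1 `C[C@@H](c1ccc2ncccc2c1)c1nnc2ccc(-c3cccc(C#N)c3)nn12` gives 32500 nM and compound 2 `Cc1cccc(-c2ccc3nnc([C@@H](C)c4ccc5ncccc5c4)n3n2)c1` gives 19000 nM, so compound 2 stands within the usual scatter of its only measured neighbour.

The next compound, compound 3 `C[C@@H](c1ccc2ncccc2c1)c1nnc2ccc(-c3ccc(N(C)C)nc3)nn12`, carries 6-(dimethylamino)pyridin-3-yl in place of the 3-methylphenyl of compound 2, on an aromatic carbon of a six-membered aromatic ring with 2 nitrogen (6-(dimethylamino)pyridin-3-yl in place of 3-methylphenyl on an aromatic carbon).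

Among the compounds with values here, only one measured step bears on this change: a 1.7-fold lower number from compound 1 to compound 2 (0.23 log units; within the scatter), for methyl in place of cyano on an aromatic carbon. That step lies within the scatter, but it altered one substituent on the group that now leaves, whereas here the whole group is replaced. Within the data shown here, no measured compound carries the entering group, so the guidance is weak and the range must stay wide.

No shift beyond the scatter is expected, and the estimated move is a 1.3-fold higher number from compound 2 to compound 3 (0.12 log units; within the scatter) in size. The estimate for compound 3 is 25000 nM as a middle value, with an expected range from 8000 nM to 70000 nM across repeat measurements.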

Compound 3, solubility: 16200 nM
For compound 3 the middle estimate is 1.5-fold (0.19 log units) above the measured one, within the range that was stated.
By their numbers in this assay, from the lowest: compounds 3, 2 and 1 (each within the scatter of the next).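

In this assay, putting 6-(dimethylamino)pyridin-3-yl on this aromatic carbon gives a 1.2-fold lower number from compound 2 to compound 3 (0.07 log units; within the scatter) when it takes the place of 3-methylphenyl, and a 2.0-fold lower number from compound 1 to compound 3 (0.30 log units; within the scatter) when it takes the place of 3-cyanophenyl. Going by these compounds alone, the earlier step changed only one substituent on a phenyl ring, whereas these steps replace the whole group with a larger one that has a nitrogen in its ring and a dimethylamino group, and still no step goes beyond the scatter. Among these three compounds, then, this position has taken three different aromatic groups with no clear difference in the read-out, and no measurement on hand offers an explanation for this result.

The entering group changes two things at once, so the ring nitrogen and the dimethylamino group cannot be judged apart; a plain pyridin-3-yl, or a dimethylamino group on a phenyl ring, would separate them. From the compounds shown here alone, it also remains open whether a carboxylic acid or a piperazine at this position would give a step beyond the scatter.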